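The compounds below may be only part of what the source reports. "The series", "measured", "known", "first", "only" and "open" are said of these compounds alone.

Measured so far in an ADME assay on C8166 cells (Homo sapiens) for cytotoxicity, read by MTT assay; a lower number here means that less compound is tolerated, a higher number that more compound is tolerated:
- compound 1 `Cc1cc(S(N)(=O)=O)ccc1NC(=O)COc1ccc(Cl)cc1Oc1ccc2ccccc2c1Cl` gives 40700 nM
- compound 2 `Cc1cc(S(N)(=O)=O)ccc1NC(=O)COc1ccc(F)cc1Oc1cc2ccccc2cc1C` gives 66900 nM

Compound 2 holds the highest of the two numbers in this assay, but compound 1 sits within the scatter of it, so the two values show no separation that can be read as a difference in tolerated concentration.

Compound 3 `Cc1cc(S(N)(=O)=O)ccc1NC(=O)COc1ccc(F)cc1Oc1ccc2cc(C#N)ccc2c1` is the next candidate for this assay. Against compound 2 it differs by 6-cyanonaphthalen-2-yl in place of 3-methylnaphthalen-2-yl on an oxygen on an aromatic ring. For the measured compounds named here, no measured pair isolates this change, so nothing in the data anchors its effect on cytotoxicity. Going by the values given here, both measured values lie close together, and with no step in hand the expectation is that the step from compound 2 to compound 3 stays within the scatter rather than moving clearly in either direction. The estimated step is a 1.2-fold lower number from compound 2 to compound 3 (0.09 log units; within the scatter). Compound 3 is therefore expected to give about 55000 nM in this assay, with a range from 25000 nM to 120000 nM.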

Compound 3, half-maximal cytotoxic concentration: > 395000 nM
Compound 3 was reported as a limit; the forecaster's own chance of this, stated with the estimate: 20%; middle value at least 7.1-fold (0.85 log units) from the limit.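

For the compounds shown here, the change from 3-methylnaphthalen-2-yl to 6-cyanonaphthalen-2-yl on an oxygen on an aromatic ring gives an at least 5.9-fold higher number from compound 2 to compound 3 (0.77 log units; beyond the scatter) in this assay, the first step that can be read. The group at this position can therefore shift the tolerated concentration beyond the scatter, which compound 1 and compound 2, differing in more than one place, could not show. Compound 3 is reported as a limit and not as a number, so the step has a lower end only: the limit of > 395000 nM in this assay, at which 1 of the 3 values shown sits.

The compounds shown do not separate the contribution of the nitrile from that of losing the methyl. On these data alone, whether an amine or a carboxylic acid in place of the nitrile would give a similar step also remains open.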